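Dimethylamino in place of methoxy on compound 1

This account rests on a few compounds, and the source may have more. Where it says the series, first, only, none or still open, it means among the compounds named here.

Three related compounds have been measured in a functional assay on the whole organism for agonist activity, with Mus musculus as the target; a lower number here means that less compound is needed, a higher number that more compound is needed for the effect. Compound 1 `COC(=O)N(C)CC#CCN1CCCC1` gives 1.4 mg/kg, compound 2 `COC(=O)N(C)CC#CCn1ccnc1` gives 2 mg/kg, and compound 3 `COC(=O)N(C)C(C)C#CCN1CCCC1` gives 9.7 mg/kg. Compound 1 therefore stands level with compound 2 within the scatter, while compound 3 lies clearly above it.

The next compound, compound 4 `CN(C)C(=O)N(C)CC#CCN1CCCC1`, carries dimethylamino in place of methoxy on a carbonyl carbon. Neither measured step touches that place, so both bear on it only indirectly. Placing 1H-imidazol-1-yl where pyrrolidin-1-yl stood gave a 1.4-fold higher number from compound 1 to compound 2 (0.15 log units; within the scatter). Placing methyl where hydrogen stood, on a saturated chain carbon bound to an amide-type nitrogen and a triple-bonded carbon, gave a 6.9-fold higher number from compound 1 to compound 3 (0.84 log units; beyond the scatter). These steps show that, in this small set, one change left the number within the scatter and the other moved it upward. For the measured compounds named here, no measured compound differs at the carbonyl carbon, so the direction of the new step remains uncertain. A modest rise in this assay is expected, no larger than the rise seen with compound 3 at 9.7 mg/kg, and the expected step is a 3.6-fold higher number from compound 1 to compound 4 (0.55 log units; beyond the scatter). Compound 4 is estimated at 5 mg/kg, with an expected range from 1.2 mg/kg to 20 mg/kg.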

Compound 4, dose for half-maximal effect: 1.2 mg/kg
The estimate for compound 4 lay 4.2-fold (0.62 log units) above the measured number; the range from low to high includes it.
By their numbers in this assay, from the lowest: compounds 4, 1 and 2 (each within the scatter of the next); then compound 3.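

In this assay, for the compounds shown here, the exchange of methoxy for dimethylamino on a carbonyl carbon, whose other neighbour is the amide-type nitrogen, gave a 1.2-fold lower number from compound 1 to compound 4 (0.07 log units; within the scatter) and so offers the first reading at this place, since the earlier steps concerned other parts of the molecule. Methoxycarbonyl can therefore give way to dimethylcarbamoyl with no change that stands out from the scatter, whereas methyl on the saturated chain carbon gave a 6.9-fold higher number from compound 1 to compound 3 (0.84 log units; beyond the scatter) in the same assay, so of the two places the number has so far responded only at that chain carbon. No measurement of any other property accompanies these numbers, so the data offer no explanation for the result.

Going by these compounds alone, the carbonyl carbon has been read with only this one exchange, which leaves open whether ethoxy, a primary amine or a longer chain there would also keep the number within the scatter of compound 1. It also remains open whether dimethylcarbamoyl would behave the same way alongside 1H-imidazol-1-yl or the added methyl, since each step shown starts from compound 1 and changes a single place.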